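Hydrazone aryl swap in a diaryl ether urea series

A few compounds are considered here, and "the series" means these few. Any claim that something is new, unique, unknown or untested is made for them only; others in the source may bear on it.

compound 1 `COc1ccc(/C=N/NC(=O)Nc2ccc(Oc3ccnc(-c4nncn4CCN(C)C)c3)c(F)c2)c(OC)c1`: 12600 nM
compound 2 `COc1ccc(/C=N/NC(=O)Nc2ccc(Oc3ccnc(-c4nncn4CCN(C)C)c3)c(F)c2)c(OC)c1OC`: 7650 nM

In a functional assay on U-87MG ATCC cells (Homo sapiens) for cytotoxicity, read by MTT assay, with a stated time of 72 h (on this read-out lower numbers stand for stronger inhibition and higher numbers for weaker inhibition), compound 2 sits at the low end of the two numbers, with compound 1 within the scatter of it (a 1.6-fold lower number from compound 1 to compound 2 (0.22 log units; within the scatter)). Compound 3 `CN(C)CCn1cnnc1-c1cc(Oc2ccc(NC(=O)N/N=C/c3cccc(O)c3)cc2F)ccn1` differs from compound 2 by 3-hydroxyphenyl in place of 2,3,4-trimethoxyphenyl on a carbon with a double bond to nitrogen. Among the measured compounds shown here, the only measured step, a 1.6-fold lower number from compound 1 to compound 2 (0.22 log units; within the scatter), adds one methoxy and stays within the scatter; no step removes all three methoxy groups or brings in a hydroxyl, so it bears on the change only loosely. No step beyond the scatter is expected in either direction. Compound 3 is estimated at 10000 nM, range 3000 nM to 40000 nM, an expected step of a 1.3-fold higher number from compound 2 to compound 3 (0.12 log units; within the scatter).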

Compound 3, half-maximal inhibitory concentration: > 100000 nM
Compound 3 gave a limit, no number; the forecaster's own chance of this, stated with the estimate: 10%; at least 10-fold (1.00 log units) between middle value and limit.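

In this assay compound 3 gives a limit of the assay, not a number: the limit of > 100000 nM in this assay, at which 1 of the 3 values shown sits.

The aryl group on this carbon with a double bond to nitrogen does matter: 3-hydroxyphenyl in place of 2,3,4-trimethoxyphenyl gives an at least 13-fold higher number from compound 2 to compound 3 (1.11 log units; beyond the scatter), and in place of 2,4-dimethoxyphenyl it gives an at least 7.9-fold higher number from compound 1 to compound 3 (0.89 log units; beyond the scatter). Among the compounds shown here, the single methoxy step between the earlier compounds stayed within the scatter and did not show this.

Losing the methoxy groups and gaining the hydroxyl happen together here, so the two changes remain unseparated. An unsubstituted phenyl or an aminophenyl would bear on that question.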